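Working notes: nitro in place of methyl, compound 4

A few compounds are considered here, and "the series" means these few. Any claim that something is new, unique, unknown or untested is made for them only; others in the source may bear on it.

In an ADME assay on MT4 cells (Homo sapiens) for cytotoxicity, read by MTT assay (on this read-out higher numbers stand for lower toxicity in this test and lower numbers for higher toxicity in this test), compound 1 (`Cc1ccccc1C(=O)N(C(=S)OCCN1C(=O)c2ccccc2C1=O)c1ccc(Cl)cc1`) gives 21000 nM, compound 2 (`O=C1c2ccccc2C(=O)N1CCOC(=S)N(C(=O)c1ccccc1[N+](=O)[O-])c1ccc(Cl)cc1`) gives 21000 nM and compound 3 (`Cc1cccc(C(=O)N(C(=S)OCCN2C(=O)c3ccccc3C2=O)c2ccc(Cl)cc2)c1`) gives 58000 nM. The last of these is the highest number of the three, and the two steps that reach it are modest: a 2.8-fold higher number from compound 1 to compound 3 (0.44 log units; beyond the scatter) and a 2.8-fold higher number from compound 2 to compound 3 (0.44 log units; beyond the scatter).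

Compound 4 (`O=C1c2ccccc2C(=O)N1CCOC(=S)N(C(=O)c1cccc([N+](=O)[O-])c1)c1ccc(Cl)cc1`) has not yet been measured. It carries nitro in place of methyl on an aromatic carbon, meta to a large group, so that 3-methylphenyl becomes 3-nitrophenyl: nitro in place of methyl on an aromatic carbon.

Among the measured compounds shown here, the closest precedent is the same exchange of methyl for nitro on an aromatic carbon, which gave no change at the digits printed from compound 1 to compound 2 (within the scatter). Going by these compounds, that is a single pair, and it sits at a different place on the ring, so its transfer to the present pair is untested. The two modest steps ending at compound 3 also show that the number can move when the aryl group on the carbonyl carbon changes. On this evidence, no step beyond the scatter is expected in this assay, and the estimated outcome is a 1.2-fold lower number from compound 3 to compound 4 (0.08 log units; within the scatter). Compound 4 is estimated at 48000 nM, with an expected range from 21000 nM to 110000 nM.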

Compound 4, half-maximal cytotoxic concentration: 18000 nM
Estimate against measurement, compound 4: 2.7-fold (0.43 log units) above; the whole stated range lies above it.
By their numbers in this assay, from the lowest: compounds 4, 1 and 2 (each within the scatter of the next); then compound 3.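

Nitro in place of methyl is not a silent exchange on this aryl group in this assay: meta to a large group it gives a 3.2-fold lower number from compound 3 to compound 4 (0.51 log units; beyond the scatter), so the outcome of this change differs between the two ring places tested: the same change on two cores in this assay, no change at the digits printed (within the scatter) from compound 1 to compound 2 and a 3.2-fold lower number (0.51 log units; beyond the scatter) from compound 3 to compound 4, 3.2-fold (0.51 log units) apart, beyond the scatter of two such steps

The other two comparisons give a 1.2-fold lower number from compound 2 to compound 4 (0.07 log units; within the scatter) and a 1.2-fold lower number from compound 1 to compound 4 (0.07 log units; within the scatter), which leaves compound 3 as the only one of the four standing apart from the rest. Since 3-nitrophenyl sits at the same ring place as 3-methylphenyl without sharing its higher number, that number, which stands for lower toxicity in this test, goes with the 3-methylphenyl group in these compounds and not with the ring place alone.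

Going by these compounds, whether methyl is unusual at this ring carbon remains open, and an amine, a methoxy group or a carboxylic acid there would show whether other groups also stay level with compound 4 or reach the number of compound 3. Among the compounds shown here, with only one pair at each ring place, it is also open whether the gap between the two steps would persist with a group other than 4-chlorophenyl on the shared core.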